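A few compounds are considered here, and "the series" means these few. Any claim that something is new, unique, unknown or untested is made for them only; others in the source may bear on it.

Measured in a functional assay on L1210 cells (Mus musculus), with a stated time of 12 days; a higher number here means a more potent compound, by a factor of ten per unit of this negative logarithm, a lower number a less potent compound:
compound 1, `COCCC1=C(N2CC2)C(=O)C(C)=C(N2CC2)C1=O` — 5.42
compound 2, `CC1=C(N2CC2)C(=O)C(C(C)C)=C(N2CC2)C1=O` — 5.21
compound 3, `CC1=C(N2CC2)C(=O)C(C2CCCCC2)=C(N2CC2)C1=O` — 5.39

Within these three numbers compound 3 stands second highest. Its nearest neighbour is compound 1, with a number 0.03 log units lower from compound 1 to compound 3 (within the scatter); its furthest is compound 2, with a number 0.18 log units higher from compound 2 to compound 3 (within the scatter). The remaining pair shows a number 0.21 log units lower from compound 1 to compound 2 (within the scatter). Every step among the three is within the scatter, so the three groups on the double-bonded ring carbon are not separated by this assay.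

Compound 4, `COC(CO)C1=C(N2CC2)C(=O)C(C)=C(N2CC2)C1=O`, is unmeasured. Its change from compound 3: 2-hydroxy-1-methoxyethyl in place of cyclohexyl on a double-bonded ring carbon. The entering group carries two oxygen atoms, one hydrogen-bond donor and two hydrogen-bond acceptors, where the leaving cyclohexyl carries none. Within the data shown here, the steps that bear on this are a number 0.03 log units lower from compound 1 to compound 3 (within the scatter), which exchanges a two-oxygen-free cyclohexyl for a group that, like the entering one, holds an oxygen-bearing chain, and a number 0.18 log units higher from compound 2 to compound 3 (within the scatter). Among the measured compounds shown here, both are within the scatter, and no measured step here exceeds it, so for compound 4 the expected step is a number 0.01 log units higher from compound 3 to compound 4 (within the scatter), none beyond the scatter. Compound 4 is estimated at 5.4 in this assay, with a range from 5 to 5.8.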

Compound 4, logarithm of the reciprocal of the active concentration, log(1/C): 5.75
Compound 4: the middle estimate sits 0.35 log units below what was measured; measured number inside the range.
By their numbers in this assay, from the lowest: compounds 2, 3 and 1 (each within the scatter of the next); then compound 4.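

Working notes on the double-bonded ring carbon: in this assay this position now separates groups, as 2-hydroxy-1-methoxyethyl gives a step beyond the scatter against each of the three earlier groups: against cyclohexyl (a number 0.36 log units higher from compound 3 to compound 4 (beyond the scatter)), against isopropyl (a number 0.54 log units higher from compound 2 to compound 4 (beyond the scatter)) and against 2-methoxyethyl (a number 0.33 log units higher from compound 1 to compound 4 (beyond the scatter)). The last of these steps shows that an ether oxygen in the chain is not enough on its own, since 2-methoxyethyl stays within the scatter of both oxygen-free groups, and among the four compounds only the group with a hydroxyl stands apart. Nothing available explains why this change raises the number.

The compounds shown do not separate the hydroxyl from the branching at the carbon that carries the methoxy, so a plain 2-hydroxyethyl chain or a 2,3-dihydroxypropyl chain would be needed to tell which of the two goes with the step. As far as these compounds go, whether the step holds with an amine or a carboxylic acid at the end of the chain, or with a longer chain, also stays open.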